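Swapping the 1H-indol-5-yl group on the shared core

A few compounds are considered here, and "the series" means these few. Any claim that something is new, unique, unknown or untested is made for them only; others in the source may bear on it.

Going by the values given here, in a functional assay on CCRF-CEM cells (Homo sapiens) for inhibition, read by MTT assay, with a stated time of 72 h (a lower number here means a stronger inhibitor, a higher number a weaker inhibitor), compound 1 `COc1cc(-c2c(-c3ccc4[nH]ccc4c3)c(=O)c2=O)cc(OC)c1OC` gives 15.4 nM, the lower of the two numbers so far. Compound 2 `COc1ccc(-c2c(-c3cc(OC)c(OC)c(OC)c3)c(=O)c2=O)c(OC)c1` gives 1770 nM, a gap beyond the scatter. Compound 3 `COc1ccc(-c2c(-c3cc(OC)c(OC)c(OC)c3)c(=O)c2=O)cc1O` remains unmeasured and has 3-hydroxy-4-methoxyphenyl in place of 1H-indol-5-yl on an aromatic carbon. Among the compounds with values here, no measured step isolates this change. Compound 2 also lacks the 1H-indol-5-yl group and stands at 1770 nM, so a weaker number is expected, though with a smaller gap than that one. The estimated change is a 3.2-fold higher number from compound 1 to compound 3 (0.51 log units; beyond the scatter). For compound 3, the estimate in this assay is 50 nM, with an expected range of 10 nM to 400 nM.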

Compound 3, half-maximal inhibitory concentration: 1.7 nM
Compound 3: the middle estimate sits 29-fold (1.47 log units) above what was measured; measured number outside the range, below it.
By their numbers in this assay, from the lowest: compound 3; then compound 1; then compound 2.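

Replacing 1H-indol-5-yl with 3-hydroxy-4-methoxyphenyl gives a 9.1-fold lower number from compound 1 to compound 3 (0.96 log units; beyond the scatter) in this assay. This position on the shared core therefore does not depend on the indole: a single six-membered aromatic ring of carbon only gives the lower number here. Nothing on hand bears on the reason for this gain.

Whether the hydroxy group of 3-hydroxy-4-methoxyphenyl accounts for the gain remains open. Also open, from the compounds shown here alone, is how an amine or a fluorine in its place would read in this assay.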